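Anilino-quinone series: phenoxy for hydroxymethyl at the aryl ring

The source may hold more compounds than are shown below. What is called first, only, known or untested is meant among the compounds shown, and "the series" means these compounds.

Compound 1 `O=C1C(Nc2ccc(CO)cc2)=CC(=O)c2ncncc21` sits at the higher of the two numbers recorded so far. In a functional assay on PANC-1 cells (Homo sapiens) for cytotoxicity, read by MTT assay, with a stated time of 72 h (a higher number here means a weaker inhibitor, a lower number a stronger inhibitor), compound 1 gives 1000 nM. Its nearest neighbour, compound 2 `COc1cccc(NC2=CC(=O)c3ncncc3C2=O)c1`, gives 600 nM in this assay; the gap between the two values falls within the scatter of this measurement, so no order between compound 1 and compound 2 can be read from them.

Compound 3 `O=C1C(Nc2ccc(Oc3ccccc3)cc2)=CC(=O)c2ncncc21` has not yet been measured in this assay. Relative to compound 1 the change is phenoxy in place of hydroxymethyl on an aromatic carbon. Among the compounds with values here, no measured pair shows this kind of exchange, so the size of the step is open. The expectation is a step from compound 1 to compound 3 of a 1.4-fold lower number from compound 1 to compound 3 (0.15 log units; within the scatter), a change not beyond the scatter. Compound 3 is estimated at 700 nM in this assay, with a range of 250 nM to 2000 nM.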

Compound 3, half-maximal inhibitory concentration: 1800 nM
Estimate against measurement, compound 3: 2.6-fold (0.41 log units) below; the measured number falls inside the stated range.
By their numbers in this assay, from the lowest: compounds 2, 1 and 3 (each within the scatter of the next, the first and the last beyond it).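

In this assay the exchange of hydroxymethyl for phenoxy on an aromatic carbon, para to a large group, gives a step of a 1.8-fold higher number from compound 1 to compound 3 (0.26 log units; within the scatter), so compound 1 and compound 3 cannot be ordered. At this position, a group of 7 heavy atoms with its own aromatic ring and no hydrogen-bond donor therefore leaves the number within the scatter of that of the much smaller hydroxymethyl. Nothing measured on these compounds speaks to a cause for this result.

From the compounds shown here alone, whether an amine, a carboxylic acid or a longer chain at the same place would give a step beyond the scatter remains open. Also open, going by these compounds, is whether a fluorine or an amine on the outer ring of the phenoxy group would shift the number in either direction.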